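Trimming one chlorine from the weakest compound

A few compounds are considered here, and "the series" means these few. Any claim that something is new, unique, unknown or untested is made for them only; others in the source may bear on it.

Measured so far:
Compound 1, `Cc1nc(-c2ccc(Cl)cc2)sc1C(=O)CSc1nc(-c2ccccc2)c(C#N)c(=O)[nH]1`, gives 83.1% in a functional assay on U-87MG ATCC cells for antiproliferative activity against U-87 MG (Homo sapiens), read by MTT assay, with a stated time of 48 h, tested at 10 uM; a higher number here means a weaker effect of the compound at the concentration tested, a lower number a stronger effect.
Compound 2, `COc1ccc(-c2nc(C)c(C(=O)CSc3nc(-c4ccc(OC)c(OC)c4)c(C#N)c(=O)[nH]3)s2)cc1`, gives 57.6% in this assay.
Compound 3, `Cc1nc(-c2ccc(Cl)cc2)sc1C(=O)CSc1nc(-c2ccc(Cl)c(Cl)c2)c(C#N)c(=O)[nH]1`, gives 97.1% in this assay.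

Of these three, compound 3 returns the highest number, which in this assay means the weakest effect on the cells at the tested concentration; its steps to compound 1 and to compound 2 both lie beyond the scatter of repeated measurements.

Compound 4, `Cc1nc(-c2ccc(Cl)cc2)sc1C(=O)CSc1nc(-c2cccc(Cl)c2)c(C#N)c(=O)[nH]1`, differs from compound 3 in one place: hydrogen in place of chloro on an aromatic carbon. Reading the difference one bond further out, the 3,4-dichlorophenyl of compound 3 becomes a 3-chlorophenyl.

Among the measured compounds shown here, one measured step bears on this change. Going from phenyl to 3,4-dichlorophenyl gave a number 14 percentage points higher from compound 1 to compound 3 (beyond the scatter). Compound 4 sits between those two end points, keeping one of the two chloro groups, so in this assay a modest step downward from compound 3, smaller than that earlier step, is expected; it may well fall within the scatter.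

Compound 4 is therefore estimated at 90%, with a range from 78% to 100%, an expected step of a number 7.1 percentage points lower from compound 3 to compound 4 (within the scatter).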

Compound 4, a percentage reported as activity, at one concentration (the size of the read-out at that concentration, not a potency): 95.2%
Compound 4: the middle estimate sits 5.2 percentage points below what was measured, within the range that was stated.
By their numbers in this assay, from the lowest: compound 2; then compound 1; then compounds 4 and 3 (each within the scatter of the next).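

In this assay, removing one chloro group from the 3,4-dichlorophenyl gives a number 1.9 percentage points lower from compound 3 to compound 4 (within the scatter), so this chloro group, ortho to the one that remains, makes no readable difference to the number at the tested concentration. Set against the unsubstituted phenyl, the single chloro group of the 3-chlorophenyl gives a number 12.1 percentage points higher from compound 1 to compound 4 (beyond the scatter), which shows that one chloro group is enough to produce a step beyond the scatter, toward a weaker effect on the cells; the earlier step, a number 14 percentage points higher from compound 1 to compound 3 (beyond the scatter), could not show this because two chloro groups entered at once. Nothing measured here explains why the first chloro group registers and the second does not.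

The compounds shown leave open whether a lone chloro group elsewhere on this phenyl ring would behave as it does in compound 4. They also do not tell whether a different group on the ring, such as an amine or a carboxylic acid, would bring the number down, toward a stronger effect, rather than up.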